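Chlorine for fluorine on the benzyl of a xanthine

This account rests on a few compounds, and the source may have more. Where it says the series, first, only, none or still open, it means among the compounds named here.

Measured compounds:
compound 1, `CCCn1c(=O)c2nc(-c3cnn(Cc4cc(Cl)ccc4Cl)c3)[nH]c2n(CCC)c1=O`, 29 nM
compound 2, `CCCn1c(=O)c2nc(-c3cnn(Cc4c(F)cccc4F)c3)[nH]c2n(CCC)c1=O`, 390 nM
compound 3, `CCCn1c(=O)c2c(nc(-n3cccn3)n2Cc2ccccc2)n(CCC)c1=O`, > 5800 nM

The three measured compounds share a core and were tested in an in vitro assay on HEK293 cells for displacement of a labelled ligand from adenosine receptor A2b (Homo sapiens); a higher number here means a weaker inhibitor, a lower number a stronger inhibitor. Compound 1 gives 29 nM. Compound 2 stands highest of the two numbers given; its nearest neighbour is compound 1, with a 13-fold higher number from compound 1 to compound 2 (1.13 log units; beyond the scatter). Compound 3 reaches only the limit of this assay, > 5800 nM, and gives no number.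

The step studied here leads from compound 2 to compound 4, `CCCn1c(=O)c2nc(-c3cnn(Cc4cc(F)ccc4Cl)c3)[nH]c2n(CCC)c1=O`. The change is 2-chloro-5-fluorophenyl in place of 2,6-difluorophenyl on a saturated chain carbon bound to an aromatic nitrogen. Compound 4 thus takes back the chlorine that compound 1 carries on the ring and keeps one fluorine. Going by the values given here, the only measured step that bears on this change is the one from compound 1 to compound 2, which was large: a 13-fold higher number from compound 1 to compound 2 (1.13 log units; beyond the scatter). Compound 4 lies between the two in structure, so a part of that step is expected to be undone, in the direction of a lower number.

Compound 4 is therefore expected to give 60 nM in this assay, between 18 nM and 200 nM, meaning an expected step of a 6.5-fold lower number from compound 2 to compound 4 (0.81 log units; beyond the scatter).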

Compound 4, inhibition constant: 4800 nM
The estimate for compound 4 lay 80-fold (1.90 log units) below the measured number; the whole stated range lies below it.
By their numbers in this assay, from the lowest: compound 1; then compound 2; then compound 4. At a limit, above all of these: compound 3.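

In this assay, exchanging 2,6-difluorophenyl for 2-chloro-5-fluorophenyl on a saturated chain carbon bound to an aromatic nitrogen did not move the number back toward that of compound 1 but further away from it, with a 12-fold higher number from compound 2 to compound 4 (1.09 log units; beyond the scatter). Going by these compounds alone, the single exchange of fluoro in place of chloro on an aromatic carbon is larger still, with a 170-fold higher number from compound 1 to compound 4 (2.22 log units; beyond the scatter), so a chlorine kept on the ring does not by itself go with a low number, and one halogen decides much of the outcome at this position. Of the numbers shown, compound 4 now stands highest, while compound 3 gives only a limit: the limit of > 5800 nM in this assay, at which 1 of the 4 values shown sits.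

The compounds shown leave open whether the step depends on fluorine in particular or whether a bromine or a methyl group in its place on the 2-chloro-5-fluorophenyl ring would bring the number back toward that of compound 1. Also open, going by these compounds, is how a 2,6-dichlorophenyl group would compare with the 2,6-difluorophenyl group of compound 2 on the same shared core.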